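A few compounds are considered here, and "the series" means these few. Any claim that something is new, unique, unknown or untested is made for them only; others in the source may bear on it.

Compound 1 `CC/N=C(\N)Nc1ccc(Sc2ccc(OC)cc2)cc1` gives 251 nM in an assay (Rattus norvegicus) for binding affinity to prostacyclin receptor (Homo sapiens), read by radioligand binding; a lower number here means a stronger inhibitor, a higher number a weaker inhibitor.
Compound 2 `CC/N=C(\N)Nc1ccc(Sc2ccc(Cl)cc2)cc1` gives 631 nM in this assay.
Compound 3 `COc1ccc(OC)c(Sc2ccc(NC3=NCCN3)cc2)c1` gives 794 nM in this assay.

Compound 1 has the lowest number of the three. Among the measured compounds shown here, the only single-point step, from compound 1 to compound 2, is a 2.5-fold higher number from compound 1 to compound 2 (0.40 log units; beyond the scatter), a chloro in place of methoxy on an aromatic carbon. Compound 4 `COc1ccc(Sc2ccc(NC3=NCCCCN3)cc2)cc1` differs from compound 1 by a group of 7 heavy atoms (5 carbon, 2 nitrogen; one seven-membered non-aromatic ring with 2 hetero atoms) in place of a group of 5 heavy atoms (3 carbon, 2 nitrogen; no ring), on a nitrogen on an aromatic ring. For the measured compounds named here, no measured step covers this kind of change; the step to compound 2 concerns another part of the molecule. Going by the values given here, compound 3 also carries a non-aromatic ring on that nitrogen, yet it differs from compound 1 in two places, so its value shows only that such a ring can go with a higher number. The expected step in this assay is a 1.6-fold higher number from compound 1 to compound 4 (0.20 log units; within the scatter), modest and uncertain. Compound 4 is therefore estimated at 400 nM, between 120 nM and 1300 nM.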

Compound 4, inhibition constant: 1260 nM
Beside the measured number, compound 4's estimate is 3.2-fold (0.50 log units) below it; low and high end bracket the measured number.
By their numbers in this assay, from the lowest: compound 1; then compounds 2, 3 and 4 (each within the scatter of the next).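

On the nitrogen on an aromatic ring, the seven-membered non-aromatic ring in place of the open-chain group gives a 5.0-fold higher number from compound 1 to compound 4 (0.70 log units; beyond the scatter) in this assay. Among the compounds shown here, this is the first reading of a change at this position alone, as compound 3 differs from compound 1 in two places, and here the ring goes with weaker binding. Nothing measured here explains the step.

On these data alone, whether a longer open chain or a simple amine on that nitrogen would keep the number of compound 1 stays open. So does whether the ring would give a similar step on compound 2.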